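The source may report more compounds than this note shows. Statements on the series, on what has been measured and on what is new or still open speak of the compounds shown alone.

Measured compounds, all in a functional assay on aorta (strain Wistar) for inhibition, with Thoracic aorta (Rattus norvegicus) as the target; a higher number here means a weaker inhibitor, a lower number a stronger inhibitor:

Compound 1 `CCOc1nc(-c2cc3ccccc3o2)cc(-c2ccc3ccccc3c2)c1C#N` gives 423000 nM.
Compound 2 `CCOc1nc(-c2cc3ccccc3o2)cc(-c2ccc(OC)cc2)c1C#N` gives 204000 nM.
Compound 3 `CCOc1nc(-c2cc3ccccc3o2)cc(-c2ccc(OC)cc2OC)c1C#N` gives 488000 nM.

Compound 3 stands at the highest of the three numbers. Its nearest neighbour is compound 1, where the difference is a 1.2-fold higher number from compound 1 to compound 3 (0.06 log units; within the scatter), so the two cannot be told apart. For the measured compounds named here, the one step that clearly separates it is a 2.4-fold higher number from compound 2 to compound 3 (0.38 log units; beyond the scatter), a modest step in the weakening direction. The other step in the set, a 2.1-fold lower number from compound 1 to compound 2 (0.32 log units; beyond the scatter), is of similar size the other way.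

Compound 4 `CCOc1nc(-c2cc3ccccc3o2)cc(-c2ccc(N(C)C)cc2)c1C#N` is not yet measured. The change is 4-(dimethylamino)phenyl in place of 2,4-dimethoxyphenyl on an aromatic carbon. Two things happen at once: the extra methoxy of compound 3 is gone, and the remaining methoxy is exchanged for a dimethylamino group. The first part is the reverse of what is seen in a 2.4-fold higher number from compound 2 to compound 3 (0.38 log units; beyond the scatter), which on its own would bring the number back toward that of compound 2. Going by the values given here, the second part, methoxy to dimethylamino on this aromatic carbon, has no measured counterpart here, so its size cannot be set from the data and only adds uncertainty.

Taking the reversal of the methoxy step as the main guide, a modest lowering is expected, a 2.0-fold lower number from compound 3 to compound 4 (0.29 log units; within the scatter). The expected value for compound 4 in this assay is 250000 nM, with a range of 100000 nM to 600000 nM.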

Compound 4, half-maximal inhibitory concentration: 338000 nM
Estimate against measurement, compound 4: 1.4-fold (0.13 log units) below; the measured number falls inside the stated range.
By their numbers in this assay, from the lowest: compounds 2, 4, 1 and 3 (each within the scatter of the next, the first and the last beyond it).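

Opposite the ring nitrogen, 4-(dimethylamino)phenyl cannot be told apart in this assay from any of the three earlier groups: a 1.4-fold lower number from compound 3 to compound 4 (0.16 log units; within the scatter), a 1.7-fold higher number from compound 2 to compound 4 (0.22 log units; within the scatter), and a 1.3-fold lower number from compound 1 to compound 4 (0.10 log units; within the scatter). The exchange of methoxy for dimethylamino on the phenyl ring, the first change of this kind in the series, therefore gives no measurable separation, whereas adding a second methoxy did give one, with a 2.4-fold higher number from compound 2 to compound 3 (0.38 log units; beyond the scatter). No measurement at hand bears on the reason for either outcome.

The compounds shown leave open whether a phenyl ring carrying a carboxylic acid, a hydroxy group, a chloro group or a longer alkoxy chain at this position would move the number beyond the scatter from compound 2. They also leave open how far the ethoxy group and the 1-benzofuran-2-yl group contribute to the values, since both stay the same throughout, and replacing the ethoxy with a primary amine, for instance, would test this directly.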